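The source may hold more compounds than are shown below. What is called first, only, known or untested is meant among the compounds shown, and "the series" means these compounds.

Compound 1 `O=S1(=O)CCc2ccc(O)cc2N1CCCCN1CCN(c2cccc3sccc23)CC1` — 13%
Compound 2 `O=c1[nH]c(=O)n(CCCCN2CCN(c3cccc4sccc34)CC2)c2ccccc12` — 80%
Compound 3 `COc1ccc2ncc(=O)n(CCCCN3CCN(c4cccc5sccc45)CC3)c2c1` — 59%

In a functional assay on the whole organism (strain ICR) with Mus musculus as the target, with stated times of 30 min, 10 min and 60 min, at a dose of 3 mg/kg by the oral route (on this read-out lower numbers stand for less inhibition and higher numbers for more inhibition at the one dose given (going by the name of the read-out)), compound 1 gives 13%, the lowest of the three numbers. Compound 3 gives 59%, a reading that lies beyond the scatter above compound 1, and compound 2 gives 80%, further still above it. The three compounds share the same chain and terminal piece, and differ only in the core that carries them.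

Compound 4 `Nc1ccc2c(c1)N(CCCCN1CCN(c3cccc4sccc34)CC1)S(=O)(=O)CC2` is not yet measured. It differs from compound 1 in one place: amino in place of hydroxy on an aromatic carbon. Going by the values given here, no pair among the measured compounds shows this change or any other single change, so there is no measured step to lean on; the only guide is the low reading of compound 1 in this assay. The change is expected to leave the reading close to where compound 1 stands, with a step from compound 1 to compound 4 of a number 7 percentage points higher from compound 1 to compound 4 (within the scatter), which is not beyond the scatter. Compound 4 is therefore estimated at 20%, with a range from 5% to 45%.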

Compound 4, a percentage reported as inhibition, in the whole organism at one dose (the size of the read-out at that dose, not a potency): 48%
Compound 4: middle estimate off by 28 percentage points, on the low side, and the stated range ends below it.
By their numbers in this assay, from the lowest: compound 1; then compound 4; then compound 3; then compound 2.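

In this assay, going by these compounds alone, amino in place of hydroxy gives a number 35 percentage points higher from compound 1 to compound 4 (beyond the scatter), so this position, on an aromatic carbon meta to a fused ring and para to a fused ring, can alter the reading on the core of compound 1, something the earlier compounds, which differ only in their cores, could not show. The two groups match in heavy-atom count, hydrogen-bond donors, hydrogen-bond acceptors and net charge, so these counts do not separate compound 1 from compound 4. No measured evidence here explains the step.

The compounds shown leave open how a methoxy group, a carboxylic acid or a dimethylamino group would read at this position. They also leave open whether amino would produce a similar step on another core.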